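Fluoro added to the chlorophenyl ring of compound 3

This account rests on a few compounds, and the source may have more. Where it says the series, first, only, none or still open, it means among the compounds named here.

Compound 1 `Cc1cc(-c2ccc(CNC(=O)CCCc3ccc4cccnc4n3)cc2)ccc1Cl` gives 300 nM in a functional assay on CHO-K1 cells for antagonist activity at succinate receptor 1 (Homo sapiens), read by FLIPR and calcium flux; on this read-out lower numbers stand for stronger inhibition and higher numbers for weaker inhibition.
Compound 2 `O=C(CCCc1ccc2cccnc2n1)NCc1ncc(-c2ccc(F)c(C(F)(F)F)c2)cn1` gives 200 nM in this assay.
Compound 3 `O=C(CCCc1ccc2cccnc2n1)NCc1cc(-c2cccc(Cl)c2)no1` gives 65 nM in this assay.

Compound 3 has the lowest number of the three, and its gaps to compound 2 and to compound 1 both lie beyond the usual scatter, so it stands as the strongest inhibitor here. Compound 4 `O=C(CCCc1ccc2cccnc2n1)NCc1cc(-c2ccc(F)c(Cl)c2)no1` differs from compound 3 only by fluoro in place of hydrogen on an aromatic carbon, turning 3-chlorophenyl into 3-chloro-4-fluorophenyl. For the measured compounds named here, no measured pair shows this exact change, so the size of the step is uncertain; a change of one atom is expected to move the number little, likely not beyond the scatter. Compound 4 is therefore estimated to give 60 nM in this assay, expected between 25 nM and 150 nM, a step of a 1.1-fold lower number from compound 3 to compound 4 (0.03 log units; within the scatter).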

Compound 4, half-maximal inhibitory concentration: 90 nM
Beside the measured number, compound 4's estimate is 1.5-fold (0.18 log units) below it; low and high end bracket the measured number.
By their numbers in this assay, from the lowest: compounds 3 and 4 (each within the scatter of the next); then compounds 2 and 1 (each within the scatter of the next).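

Fluoro in place of hydrogen, ortho to a chloro group and para to a large group, gives a 1.4-fold higher number from compound 3 to compound 4 (0.14 log units; within the scatter) in this assay, the first comparison here of compounds that differ in one place. This position therefore accepts fluoro, and the read-out cannot tell the two compounds apart. Nothing available explains this result at the level of cause.

From the compounds shown here alone, whether a bigger group at this position, such as methoxy or an amine, would give a similar number remains open.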